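The compounds below may be only part of what the source reports. "The series", "measured", "known", "first", "only" and "open" are said of these compounds alone.

In a functional assay on HUVEC cells (Homo sapiens), read by scintillation counting and thymidine incorporation, with a stated time of 24 h (a higher number here means a weaker inhibitor, a lower number a stronger inhibitor), three compounds with a shared core differ on a saturated chain carbon bound to a saturated ring carbon. Compound 1 `CCC(C)n1ncn(-c2ccc(N3CCN(c4ccc(OC[C@@H]5CO[C@@](CC)(c6ccc(Cl)cc6Cl)O5)cc4)CC3)cc2)c1=O` gives 353 nM, compound 2 `CCC(C)n1ncn(-c2ccc(N3CCN(c4ccc(OC[C@@H]5CO[C@@](CN6CCN(C)CC6)(c6ccc(Cl)cc6Cl)O5)cc4)CC3)cc2)c1=O` gives 396 nM and compound 3 `CCC(C)n1ncn(-c2ccc(N3CCN(c4ccc(OC[C@@H]5CO[C@@](Cn6cnc(C(F)(F)F)n6)(c6ccc(Cl)cc6Cl)O5)cc4)CC3)cc2)c1=O` gives 270 nM, so compound 3 sits level with both others within the scatter. Compound 4 `CCC(C)n1ncn(-c2ccc(N3CCN(c4ccc(OC[C@@H]5CO[C@@](Cn6cc(C(F)(F)F)nc6C)(c6ccc(Cl)cc6Cl)O5)cc4)CC3)cc2)c1=O` carries 2-methyl-4-(trifluoromethyl)-1H-imidazol-1-yl in place of 3-(trifluoromethyl)-1H-1,2,4-triazol-1-yl at that carbon: 2-methyl-4-(trifluoromethyl)-1H-imidazol-1-yl in place of 3-(trifluoromethyl)-1H-1,2,4-triazol-1-yl on a saturated chain carbon bound to a saturated ring carbon. The measured swaps there are small: a 1.1-fold higher number from compound 1 to compound 2 (0.05 log units; within the scatter), a 1.3-fold lower number from compound 1 to compound 3 (0.12 log units; within the scatter) and a 1.5-fold lower number from compound 2 to compound 3 (0.17 log units; within the scatter). No step beyond the scatter is therefore expected in this assay, in either direction. The estimated step is a 1.1-fold higher number from compound 3 to compound 4 (0.05 log units; within the scatter). Compound 4 is expected at 300 nM, with an estimated range from 130 nM to 700 nM.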

Compound 4, half-maximal inhibitory concentration: 441 nM
Compound 4: middle estimate off by 1.5-fold (0.17 log units), on the low side; measured number inside the range.
By their numbers in this assay, from the lowest: compounds 3, 1, 2 and 4 (each within the scatter of the next).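

Across this assay, the change to 2-methyl-4-(trifluoromethyl)-1H-imidazol-1-yl, with one ring nitrogen fewer and one more heavy atom, produces no step beyond the scatter (a 1.6-fold higher number from compound 3 to compound 4 (0.21 log units; within the scatter)), and the same holds against the other two groups (a 1.1-fold higher number from compound 2 to compound 4 (0.05 log units; within the scatter); a 1.2-fold higher number from compound 1 to compound 4 (0.10 log units; within the scatter)). This position on the saturated chain carbon has now carried four different groups, all level with one another within the scatter. No evidence here accounts for this. Going by these compounds, whether a carboxylic acid, a primary amine or a longer chain at this carbon would give a step beyond the scatter remains open.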